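Swapping the Amine Side Group on the Saturated Ring Carbon

The compounds below may be only part of what the source reports. "The series", "measured", "known", "first", "only" and "open" are said of these compounds alone.

Compound 1 `CC(C)=CCCN(C)C1CCN(CCCc2c[nH]c3ccc(-n4cnnc4)cc23)CC1` — in an assay on CHO cells for displacement of a labelled ligand from 5-hydroxytryptamine receptor 1B (Homo sapiens) (a higher number here means a weaker inhibitor, a lower number a stronger inhibitor), compound 1 gives 24 nM.
Compound 2 `CN(Cc1ccsc1)C1CCN(CCCc2c[nH]c3ccc(-n4cnnc4)cc23)CC1` — in this assay compound 2 gives 35 nM.

For the measured compounds named here, compound 2 shows the higher of the two numbers, yet the only step that reaches it, a 1.5-fold higher number from compound 1 to compound 2 (0.16 log units; within the scatter), lies within the scatter. Compound 3 `c1ccc(NCC2CCN(CCCc3c[nH]c4ccc(-n5cnnc5)cc34)CC2)nc1` carries ((pyridin-2-yl)amino)methyl in place of methyl((thiophen-3-yl)methyl)amino on a saturated ring carbon. That measured step only exchanged one substituent on the amine nitrogen; here the whole amino group leaves and a group with a hydrogen-bond donor enters, a change without any measured precedent in this set. The expected step is therefore uncertain and modestly weakening, a 2.0-fold higher number from compound 2 to compound 3 (0.30 log units; within the scatter). Compound 3 is estimated at 70 nM, in a range from 15 nM to 300 nM.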

Compound 3, half-maximal inhibitory concentration: 3.3 nM
Compound 3: the middle estimate sits 21-fold (1.33 log units) above what was measured, and the stated range ends above it.
By their numbers in this assay, from the lowest: compound 3; then compounds 1 and 2 (each within the scatter of the next).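

In this assay, ((pyridin-2-yl)amino)methyl in place of methyl((thiophen-3-yl)methyl)amino gives an 11-fold lower number from compound 2 to compound 3 (1.03 log units; beyond the scatter), and in place of methyl(4-methylpent-3-en-1-yl)amino it gives a 7.3-fold lower number from compound 1 to compound 3 (0.86 log units; beyond the scatter). Both steps lie beyond the scatter, whereas the earlier exchange of one substituent on the amine nitrogen did not, so this saturated ring carbon tolerates a replacement of the whole group and responds to it. No evidence is available on what underlies this result.

The entering group differs from those it replaces in several features at once, and these compounds do not separate them. From the compounds shown here alone, whether a phenyl ring in place of the pyridin-2-yl ring, or a methyl group on the linking nitrogen, would hold the number this low remains open.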